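Widening the amide substituent of compound 3

The compounds below may be only part of what the source reports. "The series", "measured", "known", "first", "only" and "open" are said of these compounds alone.

In a functional assay on NTUB1 cells (Homo sapiens) for cytotoxicity, read by MTT assay, with a stated time of 72 h (a lower number here means a stronger inhibitor, a higher number a weaker inhibitor), compound 1 `CCCOC(=O)c1ccc(/C=C/C(=O)c2cc(OC)ccc2OC)cc1` gives 6010 nM and compound 2 `COc1ccc(OC)c(C(=O)/C=C/c2ccc(C(=O)OCC=C(C)C)cc2)c1` gives 13400 nM while compound 3 `CNC(=O)c1ccc(/C=C/C(=O)c2cc(OC)ccc2OC)cc1` gives 2200 nM and holds the lowest number of the three. The next compound, compound 4 `COc1ccc(OC)c(C(=O)/C=C/c2ccc(C(=O)NC3CCCCC3)cc2)c1`, carries cyclohexyl in place of methyl on an amide-type nitrogen. Among the compounds with values here, no measured step changes the group on that nitrogen, so the evidence is indirect. The two steps into the amide (a 2.7-fold lower number from compound 1 to compound 3 (0.44 log units; beyond the scatter) and a 6.1-fold lower number from compound 2 to compound 3 (0.78 log units; beyond the scatter)) show that compound 3 stands lowest but say nothing about a larger amide group. The closest guide is compound 2, where a larger group on the ester chain gave a modest rise (a 2.2-fold higher number from compound 1 to compound 2 (0.35 log units; beyond the scatter)). That is one step at a different place, so the direction is only tentatively carried over. The estimated step is modest and upward (a 2.2-fold higher number from compound 3 to compound 4 (0.34 log units; beyond the scatter)). Compound 4 is expected at about 4800 nM (estimated range 1600 nM to 14000 nM).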

Compound 4, half-maximal inhibitory concentration: 2250 nM
Compound 4: the middle estimate sits 2.1-fold (0.33 log units) above what was measured; low and high end bracket the measured number.
By their numbers in this assay, from the lowest: compounds 3 and 4 (each within the scatter of the next); then compound 1; then compound 2.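

In this assay, the group on the amide-type nitrogen can grow from methyl to cyclohexyl without a readable shift: a 1.0-fold higher number from compound 3 to compound 4 (0.01 log units; within the scatter). The position therefore accepts a six-membered non-aromatic carbon ring, and the lower numbers of the amides relative to the esters are not confined to methylamino, as cyclohexylamino also shows a 2.7-fold lower number from compound 1 to compound 4 (0.43 log units; beyond the scatter) and a 6.0-fold lower number from compound 2 to compound 4 (0.77 log units; beyond the scatter). No measurement on hand bears on why the two amides give numbers within the scatter of each other.

Still open, going by these compounds, is whether this tolerance extends to a phenyl or benzyl group on the nitrogen, or to a longer chain such as hexyl. Also open, on these data alone, is how a cyclohexyl ring carrying an amine or a carboxylic acid would read, and whether a piperidine amide, which has no amide hydrogen, would keep these numbers.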